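Swapping Chloro for Bromo on Two Different Cores

A few compounds are considered here, and "the series" means these few. Any claim that something is new, unique, unknown or untested is made for them only; others in the source may bear on it.

Measured compounds:
compound 1 `O=C1C(=O)N(CN2CCN(c3ccnc4cc(Cl)ccc34)CC2)c2cc(Cl)ccc21` — 36600 nM
compound 2 `O=C1C(=O)N(CN2CCN(c3ccnc4cc(Cl)ccc34)CC2)c2cc(Br)ccc21` — 35800 nM
compound 3 `NC(=S)N/N=C1\C(=O)Nc2cccc(Cl)c21` — 24000 nM

These three compounds were tested in a functional assay on MDA-MB-468 cells (Homo sapiens) for cytotoxicity, read by sulforhodamine B assay, with a stated time of 48 h; a lower number here means a stronger inhibitor of growth, a higher number a weaker inhibitor of growth. Compound 1 and compound 2 share a core and differ only by bromo in place of chloro on an aromatic carbon. That change gave a 1.0-fold lower number from compound 1 to compound 2 (0.01 log units; within the scatter), so the two halogens behaved alike on this core. Compound 3 is built on a different core; the difference between the two cores is not broken down here. In this assay compound 3 gives 24000 nM, and the gaps to compound 1 and compound 2 are within the scatter, so no order among the three can be claimed.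

Compound 4 `NC(=S)N/N=C1\C(=O)Nc2cccc(Br)c21` is not yet measured. It differs from compound 3 by bromo in place of chloro on an aromatic carbon. This is the same kind of change as in the pair of compound 1 and compound 2, though the position is ortho to a fused ring and meta to a fused ring here, rather than meta and para. Because a 1.0-fold lower number from compound 1 to compound 2 (0.01 log units; within the scatter) was within the scatter, the step from compound 3 is expected to be small, a 1.1-fold lower number from compound 3 to compound 4 (0.04 log units; within the scatter). Compound 4 is therefore estimated at 22000 nM, likely between 10000 nM and 50000 nM.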

Compound 4, concentration for 50% growth inhibition: 21200 nM
The estimate for compound 4 lay 1.0-fold (0.02 log units) above the measured number; the range from low to high includes it.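

Putting bromo in place of chloro on the core of compound 3 gave a 1.1-fold lower number from compound 3 to compound 4 (0.05 log units; within the scatter) in this assay, and here too the two halogens behaved alike. The swap therefore left the number essentially unmoved on both cores, and the two steps cannot be told apart: the same change on two cores in this assay, a 1.0-fold lower number (0.01 log units; within the scatter) from compound 1 to compound 2 and a 1.1-fold lower number (0.05 log units; within the scatter) from compound 3 to compound 4, 1.1-fold (0.04 log units) apart, within the scatter of two such steps This does not show that the swap would stay as quiet on a third core or at another place on the ring, and two steps this small say little about whether the cores would respond alike to a change with a readable effect.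

The compounds shown carry only chloro or bromo at these places, leaving open whether a different group, such as a methoxy group, an amine or a carboxylic acid, would move the number on either core. Also open is what each core itself contributes to the number: no pair shown isolates it.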